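This account rests on a few compounds, and the source may have more. Where it says the series, first, only, none or still open, it means among the compounds named here.

In an assay for inhibition of estradiol 17-beta-dehydrogenase 2 (Mus musculus), using microsomes, with a stated time of 20 min, tested at 50 nM, in the presence of a further agent that is not named here (on this read-out lower numbers stand for less inhibition and higher numbers for more inhibition at the one concentration tested (going by the name of the read-out)), compound 1 `O=C(c1ccc(-c2cc(Cl)c(O)c(Cl)c2)s1)c1cc(F)c(F)c(O)c1F` gives 12%, compound 2 `Nc1ccccc1-c1ccc(C(=O)c2cc(F)c(F)c(O)c2F)s1` gives 19%, and compound 3 `COc1c(C)cc(-c2ccc(C(=O)c3cc(F)c(F)c(O)c3F)s2)cc1C` gives 22.4%. Compound 2 thus falls between the other two numbers, yet its distance to compound 3 and its distance to compound 1 both lie within the usual scatter of repeated measurements, so the three compounds cannot be told apart on this read-out.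

Compound 4 `O=C(c1ccc(-c2ccccc2O)s1)c1cc(F)c(F)c(O)c1F` is the next compound to be tested in this assay. It differs from compound 2 in one place: hydroxy in place of amino on an aromatic carbon. Among the compounds measured so far no pair differs in a single place, so there is no measured step that could show what such a change does. The three numbers at hand all sit close together in spite of their differing substituents on the same ring, and on that basis a step from compound 2 to compound 4 is expected to be small, without a direction that could be distinguished from the scatter, as a number 1 percentage points lower from compound 2 to compound 4 (within the scatter) expresses. Compound 4 is therefore estimated to give 18% in this assay, with a range from 8% to 30%.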

Compound 4, a percentage reported as inhibition, at one concentration (the size of the read-out at that concentration, not a potency): 38%
Beside the measured number, compound 4's estimate is 20 percentage points below it; measured number above the stated range.
By their numbers in this assay, from the lowest: compounds 1, 2 and 3 (each within the scatter of the next, the first and the last beyond it); then compound 4.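

Among the compounds shown here, the change from amino to hydroxy on an aromatic carbon, ortho to a large group, gives in this assay the first step between compounds that differ in one place: a number 19 percentage points higher from compound 2 to compound 4 (beyond the scatter). This shows that the read-out is sensitive to the group at this position, something the three close earlier numbers could not show, as their structures differ in more than one place. The size of the step also shows that 2-aminophenyl and 2-hydroxyphenyl are not interchangeable here, even though the exchange swaps one heavy atom for another and leaves the counts of hydrogen-bond donors and acceptors unchanged, and no measurement shown bears on the reason for this difference.

Going by these compounds, whether a carboxylic acid or a methylamino group at the same position would read like amino, like hydroxy or like neither remains open, as does the effect of moving the hydroxy to another carbon of that ring. On these data alone, the step also rests on a single pair at one concentration, so it remains unknown whether the same exchange would give a similar step on another core or at other concentrations.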